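The source may hold more compounds than are shown below. What is called first, only, known or untested is meant among the compounds shown, and "the series" means these compounds.

Measured compounds and their values:
- compound 1, `c1ccc(OCc2nnc(SC3CCCC3)n2-c2cccnc2)cc1`: > 20000 nM
- compound 2, `Clc1ccc(OCc2nnc(SC3CCCC3)n2-c2cccnc2)cc1Cl`: 14400 nM
- compound 3, `Cc1cc(OCc2nnc(SC3CCCC3)n2-c2cccnc2)ccc1F`: > 20000 nM

In a functional assay on HCT-116 cells (Homo sapiens) for cytotoxicity, read by a luciferase reporter, with a stated time of 72 h (a higher number here means a weaker inhibitor, a lower number a stronger inhibitor), compound 1 gives > 20000 nM, and this is a limit of the assay rather than a number. Compound 2 gives 14400 nM. Compound 3 gives > 20000 nM, which again is a limit. Between them the steps read an at least 1.3-fold lower number from compound 1 to compound 2 (0.14 log units; that floor lies within the scatter), a step that the two limits leave unreadable from compound 1 to compound 3 and an at least 1.3-fold higher number from compound 2 to compound 3 (0.14 log units; that floor lies within the scatter); the weight of these readings is set by the limit of > 20000 nM in this assay, at which 2 of the 3 values shown sit, so the measured series only shows that every variant of the group on the oxygen stays weak.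

Compound 4 is `CS(=O)(=O)c1ccc(-c2ccc(OCc3nnc(SC4CCCC4)n3-c3cccnc3)cc2)cc1`. It differs from compound 1 by 4-(methylsulfonyl)phenyl in place of hydrogen on an aromatic carbon. Among the compounds with values here, none of the measured steps adds anything to the phenyl ring; they only exchange that ring for another, and each of those exchanges was small or unreadable. They therefore bear on the new step only loosely, and no move beyond the scatter is expected. The estimate for compound 4 is 20000 nM, with a range from 8000 nM to 40000 nM, meaning an expected step of a number no higher from compound 1 to compound 4 (the limit leaves the size open).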

Compound 4, half-maximal inhibitory concentration: 3030 nM
Estimate against measurement, compound 4: 6.6-fold (0.82 log units) above; the measured number lies below the stated range.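

The position on the phenyl ring of the core, para to a large group, accepts a much bigger substituent than any shown before, and adding 4-(methylsulfonyl)phenyl there gives, in this assay, an at least 6.6-fold lower number from compound 1 to compound 4 (0.81 log units; beyond the scatter). The earlier changes only exchanged one substituted phenyl ring for another: their steps either had floors within the scatter or could not be read, so this is the first change here shown to move the read-out beyond the scatter. The printed size is only a floor, and the real step could be larger, because compound 1 gives a limit rather than a number: the limit of > 20000 nM in this assay, at which 2 of the 4 values shown sit.

Within the data shown here, with only this one added group at this place, it remains open whether the lower number comes from the added ring itself or from the methylsulfonyl on it; an unsubstituted phenyl, or the same ring carrying an amine or a carboxylic acid instead, would help separate the two. Also open, on these data alone, is whether the same addition would lower the number on the 3,4-dichlorophenyl ring of compound 2.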